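A Ring Swap on the Acid-Bearing Side of Compound 3

The source may hold more compounds than are shown below. What is called first, only, known or untested is meant among the compounds shown, and "the series" means these compounds.

Of the compounds shown here, three sharing one core have been measured. Compound 1 `Cc1c(OCCCCOc2ccc(F)c(C(N)=O)c2)ccc(C(=O)CC(C)(C)C)c1O` carries an amide on a fluorinated ring joined through a four-carbon chain; in an assay for positive allosteric modulation of metabotropic glutamate receptor 2 (Rattus norvegicus) (on this read-out lower numbers stand for an effect already at smaller amounts and higher numbers for an effect only at larger amounts of compound), compound 1 gives only a limit, > 10000 nM. Compound 2 `Cc1c(OC[C@H](C)COc2ccc(F)c(C(=O)O)c2)ccc(C(=O)CC(C)(C)C)c1O` replaces the amide with a carboxylic acid and shortens the linker to a branched chain; in this assay compound 2 gives 294 nM. Compound 3 `Cc1c(OC[C@@H](C)COc2ccc(F)c(C(=O)O)c2)ccc(C(=O)CC(C)(C)C)c1O` is its mirror partner at the branch, and in this assay compound 3 gives 112 nM. Among the measured compounds shown here, the step of a 2.6-fold lower number from compound 2 to compound 3 (0.42 log units; beyond the scatter) is the only measured step, and it arises because of the fact that compounds 2 and 3 differ only in the configuration as drawn. Compound 3 thus stands lowest of the two numbers, with compound 2 nearest.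

Compound 4 `Cc1cc(OC[C@H](C)COc2ccc(C(=O)CC(C)(C)C)c(O)c2C)ccc1C(=O)O` keeps the chain and configuration of compound 3 but exchanges the acid-bearing ring: 4-carboxy-3-methylphenyl in place of 3-carboxy-4-fluorophenyl on an oxygen on a saturated carbon. For the measured compounds named here, no measured step touches this kind of change; the one measured step concerns configuration alone and cannot guide the size here. The acid is kept, so a step of a 2.2-fold higher number from compound 3 to compound 4 (0.35 log units; beyond the scatter) is expected, modest and within or just beyond the scatter. Compound 4 is therefore estimated at 250 nM, with a likely range from 80 nM to 800 nM.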

Compound 4, half-maximal effective concentration: 305 nM
Compound 4: middle estimate off by 1.2-fold (0.09 log units), on the low side, and the stated range covers the measured number.
By their numbers in this assay, from the lowest: compound 3; then compounds 2 and 4 (each within the scatter of the next). At a limit, above all of these: compound 1.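

In this assay, among the compounds shown here, exchanging the ring on an oxygen on a saturated carbon gives a 2.7-fold higher number from compound 3 to compound 4 (0.44 log units; beyond the scatter), so this is the first measured sign that the acid-bearing ring can be replaced with only a modest shift in the number. The swap changes more than one feature at once: the fluorine leaves, a methyl enters, and 3-carboxy becomes 4-carboxy, although both groups keep a carboxylic acid and the same number of heavy atoms, so this single step cannot divide its size among those features. Nothing measured here explains why the number moves in this direction.

The compounds shown leave open which of these features carries the shift, and whether a tetrazole in place of the carboxylic acid or a chlorine in place of the methyl would keep the number close to that of compound 4. They also leave open whether the mirror form at the branch would shift the number on 4-carboxy-3-methylphenyl as it does on 3-carboxy-4-fluorophenyl, where the step is a 2.6-fold lower number from compound 2 to compound 3 (0.42 log units; beyond the scatter).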